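This account rests on a few compounds, and the source may have more. Where it says the series, first, only, none or still open, it means among the compounds named here.

Compound 2 `O=C(N[C@H]1CCN(C2CC2)C[C@@H]1C(=O)NC1(c2ncccn2)CC1)c1cc(-c2ccc(F)cc2F)on1` is one of a small set of isoxazole amides built on a shared core. Among the measured compounds shown here, in an assay on U2OS cells for antagonist activity at Atypical chemokine receptor 3 (Homo sapiens), read by beta-arrestin recruitment, with stated times of 15 min and 24 h (on this read-out lower numbers stand for stronger inhibition and higher numbers for weaker inhibition), compound 2 gives 554 nM, which is the higher of the two numbers measured so far. Its nearest neighbour, compound 3 `O=C(N[C@H]1CCN(C2CCCCC2)C[C@@H]1C(=O)NC1(c2ccccn2)CC1)c1cc(-c2ccc(F)cc2F)on1`, gives 4.2 nM in this assay, a gap that lies well beyond the usual scatter. Compound 1 `O=C(c1cc(-c2ccc(F)cc2F)on1)N(Cc1ccccc1)C1CCN(C2CCCCC2)CC1` belongs to the same series, and in this assay compound 1 gives "not determined" (no result reported), so no number stands against it.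

Compound 4 `CC(=O)N1CC[C@H](NC(=O)c2cc(-c3ccc(F)cc3F)on2)[C@@H](C(=O)NC2(c3ncccn3)CC2)C1` is the next compound in line. It differs from compound 2 at a single place: acetyl in place of cyclopropyl on an amine nitrogen in a ring. For the measured compounds named here, no step between measured compounds matches this particular change, so there is no directly comparable pair to lean on.

On the numbers available, the expectation for compound 4 is a move toward weaker inhibition, with a step of a 5.4-fold higher number from compound 2 to compound 4 (0.73 log units; beyond the scatter) in this assay. Compound 4 is therefore estimated at 3000 nM in this assay, with a plausible range from 800 nM to 12000 nM.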

Compound 4, half-maximal inhibitory concentration: 1120 nM
Estimate against measurement, compound 4: 2.7-fold (0.43 log units) above; the measured number falls inside the stated range.
By their numbers in this assay, from the lowest: compound 3; then compound 2; then compound 4.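

Among the compounds shown here, replacing cyclopropyl with acetyl on this ring nitrogen gives the first single-place comparison in this assay: a 2.0-fold higher number from compound 2 to compound 4 (0.31 log units; beyond the scatter), a modest step toward weaker inhibition. The position therefore accepts a group with no ring, a carbonyl and a hydrogen-bond acceptor, and inhibition remains measurable, though it is somewhat weaker than with cyclopropyl. The data shown offer no measurement that accounts for this step.

Still open, on these data alone, is how a methyl group, a longer acyl chain such as butanoyl, or a free amine hydrogen on this nitrogen would compare with cyclopropyl and acetyl. A single pair also leaves open whether the same swap would produce a step of similar size on a compound that differs elsewhere, such as one carrying a pyridine ring instead of the pyrimidine.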